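This account rests on a few compounds, and the source may have more. Where it says the series, first, only, none or still open, it means among the compounds named here.

Compounds measured so far:
compound 1 `CC(C)[C@@H]1CC[C@@H](C)C[C@@]12N(C)C(=O)[C@@H]1[C@H]3C(=O)N(C)C(=O)[C@H]3ON12`, 75.3%;
compound 2 `COc1ccc(N2C(=O)[C@H]3[C@H](ON4[C@@H]3C(=O)N(C)[C@@]43C[C@H](C)CC[C@H]3C(C)C)C2=O)cc1`, 75.1%;
compound 3 `Cc1cccc(N2C(=O)[C@H]3[C@H](ON4[C@@H]3C(=O)N(C)[C@@]43C[C@H](C)CC[C@H]3C(C)C)C2=O)c1`, 52.4%.

In a functional assay, read by spectrophotometry, with a stated time of 2 h, tested at 3 mg/mL (a lower number here means a weaker effect, a higher number a stronger effect of the compound at the concentration tested), compound 3 stands lowest of the three, with compound 2 nearest and compound 1 furthest, both beyond the scatter. Compound 4 `CC(C)[C@@H]1CC[C@@H](C)C[C@@]12N(C)C(=O)[C@@H]1[C@H]3C(=O)N(c4ccc5ccccc5c4)C(=O)[C@H]3ON12` differs from compound 3 by naphthalen-2-yl in place of 3-methylphenyl on an amide-type nitrogen in a ring. Within the data shown here, no measured step swaps one aryl group for a larger one; the nearest comparisons are a number 22.9 percentage points lower from compound 1 to compound 3 (beyond the scatter) and a number 22.7 percentage points lower from compound 2 to compound 3 (beyond the scatter), both modest drops, while a number 0.2 percentage points lower from compound 1 to compound 2 (within the scatter) lay within the scatter. Among the measured compounds shown here, with no direct precedent, compound 4 is expected to show no step beyond the scatter, a number 2.6 percentage points higher from compound 3 to compound 4 (within the scatter). Compound 4 is therefore estimated at 55%, between 35% and 75%.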

Compound 4, a percentage reported as activity, at one concentration (the size of the read-out at that concentration, not a potency): 60.1%
For compound 4 the middle estimate is 5.1 percentage points below the measured one; measured number inside the range.
By their numbers in this assay, from the lowest: compounds 3 and 4 (each within the scatter of the next); then compounds 2 and 1 (each within the scatter of the next).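

In this assay the change to naphthalen-2-yl gives a number 7.7 percentage points higher from compound 3 to compound 4 (within the scatter) and so, within the scatter, adds nothing to the level of the 3-methylphenyl compound, even with its second aromatic ring. It also gives a number 15 percentage points lower from compound 2 to compound 4 (beyond the scatter) and a number 15.2 percentage points lower from compound 1 to compound 4 (beyond the scatter) so that compound 3 and compound 4 both stand apart from compound 1 and compound 2, while the 4-methoxyphenyl of compound 2 shows that an aryl group here need not lower the number. Nothing measured accounts for these differences. Still open, from the compounds shown here alone, is whether a benzylamine, a benzoic acid or a longer alkyl chain on this nitrogen would keep the number near that of compound 1.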